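A few compounds are considered here, and "the series" means these few. Any claim that something is new, unique, unknown or untested is made for them only; others in the source may bear on it.

Measured so far:
compound 1, `CC(C)(C)Cc1c(-c2ccc(F)cc2)sc(N)c1C(=O)c1ccc(Cl)cc1`: 1%
compound 2, `CC(C)(C)Cc1c(-c2cccc(F)c2F)sc(N)c1C(=O)c1ccc(Cl)cc1`: 1%

In an assay on CHO cells for displacement of a labelled ligand from adenosine receptor A1 (Homo sapiens), read by scintillation counting, tested at 10 uM (a lower number here means less inhibition, a higher number more inhibition at the concentration tested (going by the name of the read-out)), compound 1 gives 1% and compound 2 gives 1%. Compound 2 thus stands level with compound 1 at the digits shown; the only measured step, no change at the digits printed from compound 1 to compound 2 (within the scatter), lies within the scatter. Compound 3, `CC(C)(C)Cc1c(-c2ccc(F)cc2F)sc(N)c1C(=O)c1ccc(Cl)cc1`, has not yet been measured in this assay. It differs from compound 2 in one place: 2,4-difluorophenyl in place of 2,3-difluorophenyl on an aromatic carbon. The two have the same atoms, joined differently. For the measured compounds named here, the one step that bears on this change, no change at the digits printed from compound 1 to compound 2 (within the scatter), also exchanged one fluorinated phenyl group for another on the same aromatic carbon and stayed within the scatter. Nothing else in the data points in either direction, so the step is expected to be none beyond the scatter: no change at the digits printed from compound 2 to compound 3 (within the scatter). Compound 3 is therefore estimated at 1% in this assay, with a range from -8% to 10%.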

Compound 3, a percentage reported as inhibition, at one concentration (the size of the read-out at that concentration, not a potency): 1%
For compound 3 middle estimate and measured number coincide at the digits printed; the range from low to high includes it.
By their numbers in this assay, from the lowest: compounds 1, 2 and 3 (each within the scatter of the next).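

In this assay the exchange of 2,3-difluorophenyl for 2,4-difluorophenyl on the aromatic carbon next to the ring sulfur gives no measurable difference (no change at the digits printed from compound 2 to compound 3 (within the scatter)). The earlier step changed the fluorinated phenyl group as a whole, whereas compound 3 also isolates a single fluoro in place of hydrogen on that phenyl group, and this too leaves the reading unmoved (no change at the digits printed from compound 1 to compound 3 (within the scatter)). No measurement shown here offers an explanation for these flat readings.

The compounds shown leave open whether a methoxy group or an amine on this phenyl group, or a carboxylic acid in its place, would give a reading that differs from that of compound 3 (1%). They also leave open whether a longer chain in place of the neopentyl group would change the reading.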